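This account rests on a few compounds, and the source may have more. Where it says the series, first, only, none or still open, it means among the compounds named here.

In a functional assay on DLD-1 cells (Homo sapiens) for antiproliferative activity, read by CellTiter-Glo, with a stated time of 72 h (on this read-out lower numbers stand for stronger inhibition and higher numbers for weaker inhibition), compound 1 `CC1CCN(C2CCN(S(=O)(=O)c3ccc(F)cc3F)CC2)CC1` gives 102 nM, the higher of the two numbers shown, while compound 2 `COc1ccccc1-c1ccc(S(=O)(=O)N2CCC(N3CCC(C)CC3)CC2)cc1` gives 26 nM, a separation that lies beyond the scatter. Compound 3 `Cc1cc(C)c(S(=O)(=O)c2ccc(N3CCC(C)CC3)cc2)c(C)c1` reaches only a limit of the assay, > 5000 nM, which is the limit of > 5000 nM in this assay, at which 1 of the 3 values shown sits. Compound 4 `CC1CCN(C2CCN(S(=O)(=O)c3ccc(Cl)nc3)CC2)CC1` carries a single change relative to compound 1: 6-chloropyridin-3-yl in place of 2,4-difluorophenyl on a sulfonyl sulfur. Among the compounds with values here, no step between measured compounds joins such a pair, so the size of this change has no precedent here; a shift within or close to the scatter is expected, with no clear direction. Compound 4 is therefore expected near 150 nM, with a range from 50 nM to 450 nM. The step of a 1.5-fold higher number from compound 1 to compound 4 (0.17 log units; within the scatter) that this estimate means is expected to stay within the scatter.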

Compound 4, half-maximal inhibitory concentration: 3700 nM
Beside the measured number, compound 4's estimate is 25-fold (1.39 log units) below it; the whole stated range lies below it.
By their numbers in this assay, from the lowest: compound 2; then compound 1; then compound 4. At a limit, above all of these: compound 3.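

At this place, on a sulfonyl sulfur whose other neighbour is a sulfonamide nitrogen in a ring, the aromatic group is far from freely exchangeable: in this assay, 6-chloropyridin-3-yl in place of 2,4-difluorophenyl produces a 36-fold higher number from compound 1 to compound 4 (1.56 log units; beyond the scatter), a large step. Even one aromatic ring exchanged for another on an otherwise unchanged compound is enough to cost this much. Nothing measured here accounts for the loss. Going by these compounds, whether the ring nitrogen or the chlorine carries the step remains open. So does whether a plain phenyl or a 4-chlorophenyl on the same sulfur would stay close to compound 1.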